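One Methyl on an Oxygen, Measured Once, Expected Again

A few compounds are considered here, and "the series" means these few. Any claim that something is new, unique, unknown or untested is made for them only; others in the source may bear on it.

Three compounds have been measured in a functional assay on T47D cells (Homo sapiens) for antiproliferative activity, read by MTT assay, with a stated time of 48 h; on this read-out higher numbers stand for weaker inhibition and lower numbers for stronger inhibition:

compound 1 `N#Cc1ncn(-c2ccc(F)cc2)c1/N=C/c1ccc(O)cc1` — 20400 nM
compound 2 `COc1ccc(/C=N/c2c(C#N)ncn2-c2ccc(F)cc2)cc1` — 19400 nM
compound 3 `COc1ccc(/C=N/c2c(C#N)ncn2Cc2ccc(F)cc2)cc1O` — 6140 nM

Compound 3 gives the lowest of the three numbers, and its gaps to compound 1 and compound 2 both lie beyond the scatter. The change from compound 1 to compound 2 is methyl in place of hydrogen on an oxygen on an aromatic ring and it produced a 1.1-fold lower number from compound 1 to compound 2 (0.02 log units; within the scatter). Compound 4 `COc1ccc(/C=N/c2c(C#N)ncn2Cc2ccc(F)cc2)cc1OC` carries the same change relative to compound 3, namely (methyl in place of hydrogen on an oxygen on an aromatic ring); the surroundings of the place are the same in both pairs. How the core of compound 1 differs from that of compound 3 is not broken down here. Because the earlier step was a 1.1-fold lower number from compound 1 to compound 2 (0.02 log units; within the scatter), compound 4 is expected to show a 1.1-fold lower number from compound 3 to compound 4 (0.04 log units; within the scatter), within the scatter of compound 3. The estimate for compound 4 in this assay is therefore 5600 nM, expected between 2500 nM and 12500 nM.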

Compound 4, half-maximal inhibitory concentration: 8200 nM
Estimate against measurement, compound 4: 1.5-fold (0.17 log units) below; low and high end bracket the measured number.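

In this assay, methyl in place of hydrogen on an oxygen on an aromatic ring gave a 1.3-fold higher number from compound 3 to compound 4 (0.13 log units; within the scatter), so hydroxy to methoxy again left the number within the scatter. Set beside the earlier step, the change reads alike on the two cores: the same change on two cores in this assay, a 1.1-fold lower number (0.02 log units; within the scatter) from compound 1 to compound 2 and a 1.3-fold higher number (0.13 log units; within the scatter) from compound 3 to compound 4, 1.4-fold (0.15 log units) apart, within the scatter of two such steps. This shows that the change carried over between these two pairs in this one assay, but it does not show that it would stay this small on any other core or in any other assay.

The compounds shown leave open whether an ethyl group or a longer chain on that oxygen would behave as methyl did. They also leave open what an amine or a carboxylic acid in place of the hydroxy would do.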